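A few compounds are considered here, and "the series" means these few. Any claim that something is new, unique, unknown or untested is made for them only; others in the source may bear on it.

Compound 2 `CC(=O)Nc1nc(-c2cccc(NS(=O)(=O)c3ccc(C#C[Si](C)(C)C)cc3)c2)cs1` holds the higher of the two numbers recorded so far in a functional assay on A-375 cells (Homo sapiens) for antiproliferative activity, read by trypan blue exclusion, with a stated time of 48 h, tested at 5 uM (on this read-out lower numbers stand for a stronger effect and higher numbers for a weaker effect at the one concentration tested), where compound 2 gives 4.2%. Going by the values given here, its only neighbour is compound 1 `CC(=O)Nc1nc(-c2cccc(NS(=O)(=O)c3ccc(C#CC4CCCCC4)cc3)c2)cs1`, which in this assay gives 1.2%; the step of a number 3 percentage points higher from compound 1 to compound 2 (within the scatter) stays within the scatter, so the two read-outs cannot be told apart. Compound 3 `C#Cc1ccc(S(=O)(=O)Nc2cccc(-c3csc(NC(C)=O)n3)c2)cc1` is not yet measured. It differs from compound 2 by a hydrogen atom in place of a group of 4 heavy atoms (3 carbon, 1 silicon; no ring), on a triple-bonded carbon. A single measured step bears on the end of the triple bond, the exchange of a group of 6 heavy atoms for a group of 4 heavy atoms, and that step, a number 3 percentage points higher from compound 1 to compound 2 (within the scatter), did not move the read-out beyond the scatter. The step of a number 2.8 percentage points higher from compound 2 to compound 3 (within the scatter) is therefore expected to stay within the scatter too, because a number 3 percentage points higher from compound 1 to compound 2 (within the scatter) showed no shift when the substituent on the triple-bonded carbon was last altered. Compound 3 is estimated to give 7% in this assay, with a range from 0.5% to 25%.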

Compound 3, a percentage reported as activity, at one concentration (the size of the read-out at that concentration, not a potency): 38.3%
For compound 3 the middle estimate is 31.3 percentage points below the measured one; measured number above the stated range.
By their numbers in this assay, from the lowest: compounds 1 and 2 (each within the scatter of the next); then compound 3.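

In this assay, replacing the group of 4 heavy atoms with a hydrogen atom on the triple-bonded carbon gives a number 34.1 percentage points higher from compound 2 to compound 3 (beyond the scatter), and replacing cyclohexyl with hydrogen gives a number 37.1 percentage points higher from compound 1 to compound 3 (beyond the scatter), so the effect is weaker whichever of the two groups leaves. Going by these compounds alone, the earlier pair showed only that these two groups could stand in for each other at this carbon, whereas compound 3 shows that the read-out does respond here once no heavy atom is attached beyond the triple bond. Nothing given here explains this difference.

The compounds shown leave open how much of a group this carbon needs, since a single methyl could give a number near either end of the range. They also leave open whether a phenyl ring or an amine-bearing chain there would match cyclohexyl.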